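Swapping the amide partner of compound 1 for a hydroxypiperidine

This account rests on a few compounds, and the source may have more. Where it says the series, first, only, none or still open, it means among the compounds named here.

The account opens with compound 1 `CCN(CC)S(=O)(=O)c1ccc(S(=O)(=O)N2CCC[C@@H](C(=O)N[C@H]3CC[C@H](OC)CC3)C2)cc1`, which in a functional assay on MIA PaCa-2 cells (Homo sapiens) for inhibition, read by MTT assay, with a stated time of 7 days (a lower number here means a stronger inhibitor, a higher number a weaker inhibitor), gives 1350 nM. Among the two compounds measured so far this is the higher of the two numbers. Going by the values given here, the other, compound 2 `O=C([C@@H]1CCCN(S(=O)(=O)c2ccc(S(=O)(=O)N3CC[C@@H](O)C3)cc2)C1)N1CCC(F)(F)CC1`, gives 210 nM in this assay, a gap that lies beyond the scatter; compound 2 differs from compound 1 at more than one place, so no single step joins them, and the two values are simply noted side by side.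

Compound 3 `CCN(CC)S(=O)(=O)c1ccc(S(=O)(=O)N2CCC[C@@H](C(=O)N3CCC(O)CC3)C2)cc1` is the next point. It carries 4-hydroxypiperidin-1-yl in place of (4-methoxycyclohexyl)amino on a carbonyl carbon, that is, 4-hydroxypiperidin-1-yl in place of (4-methoxycyclohexyl)amino on a carbonyl carbon, with the rest of compound 1 kept intact. Among the compounds with values here, no measured pair shows this change on its own, so there is no step to lean on. The expectation is a modest move toward a lower number in this assay, expressed as a 1.7-fold lower number from compound 1 to compound 3 (0.23 log units; within the scatter), and it may well stay within the scatter. For compound 3 the estimated value in this assay is 800 nM, within a range from 300 nM to 2200 nM.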

Compound 3, half-maximal inhibitory concentration: 870 nM
Beside the measured number, compound 3's estimate is 1.1-fold (0.04 log units) below it; low and high end bracket the measured number.
By their numbers in this assay, from the lowest: compound 2; then compounds 3 and 1 (each within the scatter of the next).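

Going by these compounds alone, the swap of (4-methoxycyclohexyl)amino for 4-hydroxypiperidin-1-yl on the carbonyl carbon gives the first single-place comparison in this account, and in this assay it reads as a 1.6-fold lower number from compound 1 to compound 3 (0.19 log units; within the scatter) for this change. The two groups therefore cannot be told apart in this read-out, even though the entering group is smaller, with 7 heavy atoms against 9, carries a ring hetero atom and lacks the 2 defined stereocentres of the group it replaces. This position thus accepts a secondary amide and a tertiary amide of this kind with no change that the measurement can resolve, and no independent measurement offers an explanation for that.

The compounds shown leave open whether any group at this carbonyl carbon can move the number beyond the scatter, for instance a 4-aminopiperidin-1-yl, a 4-carboxypiperidin-1-yl or an open butylamino chain. Also open, from the compounds shown here alone, is what the hydroxyl group contributes on its own, a question that a plain piperidin-1-yl at the same place would address.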